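This account rests on a few compounds, and the source may have more. Where it says the series, first, only, none or still open, it means among the compounds named here.

Measured so far:
compound 1, `CCC(C(=O)Nc1cccc(Cl)c1)N(c1ccccc1Cl)S(C)(=O)=O`, 3300 nM
compound 2, `CCS(=O)(=O)N1c2ccccc2CC[C@H]1C(=O)Nc1cccc(Cl)c1`, 2500 nM

Both compounds share the amide to the chloroaniline and a sulfonyl on nitrogen. In a functional assay on HEK293 cells for positive allosteric modulation of metabotropic glutamate receptor 5 (Rattus norvegicus), read by fluorescence and calcium flux (on this read-out higher numbers stand for an effect only at larger amounts of compound and lower numbers for an effect already at smaller amounts), compound 1 gives 3300 nM and compound 2 gives 2500 nM; the two numbers sit within the scatter of each other, so compound 2 cannot be separated from compound 1 on this read-out.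

Compound 3, `O=C(Nc1cccc(Cl)c1)[C@@H]1CCc2ccccc2N1S(=O)(=O)c1ccccc1F`, keeps the core of compound 2 and differs only in 2-fluorophenyl in place of ethyl on a sulfonyl sulfur. Going by the values given here, no measured pair shows what an aryl in place of an alkyl on the sulfonyl does, so the expected step rests on general experience alone. A small step towards a lower number is expected, about at the edge of the scatter, and a step of a 2.1-fold lower number from compound 2 to compound 3 (0.32 log units; beyond the scatter) is taken as the estimate. Compound 3 is therefore expected at 1200 nM, with a range of 300 nM to 5000 nM in this assay.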

Compound 3, half-maximal effective concentration: 6700 nM
Estimate against measurement, compound 3: 5.6-fold (0.75 log units) below; the measured number lies above the stated range.
By their numbers in this assay, from the lowest: compounds 2 and 1 (each within the scatter of the next); then compound 3.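

At this place, on a sulfonyl sulfur whose other neighbour is the sulfonamide nitrogen in a ring, the series now has its first step in one place: in this assay, 2-fluorophenyl in place of ethyl gives a 2.7-fold higher number from compound 2 to compound 3 (0.43 log units; beyond the scatter), so the position does respond to what it carries. This single pair gives the direction for this one exchange only and sets no general rule for aryl against alkyl groups on the sulfur. Nothing available explains the step.

Still open, on these data alone, is whether the step belongs to the aromatic ring or to its fluorine, which an unsubstituted phenyl on the sulfonyl would separate. Also open, as far as these compounds go, is whether a methyl or a longer chain such as propyl on the sulfur would stay level with ethyl, and how a sulfonyl-borne group carrying an amine would read.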